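A few compounds are considered here, and "the series" means these few. Any claim that something is new, unique, unknown or untested is made for them only; others in the source may bear on it.

Measured so far in a functional assay on CCRF-CEM cells (Homo sapiens) for cytotoxicity, read by MTT assay, with a stated time of 72 h; on this read-out higher numbers stand for lower toxicity in this test and lower numbers for higher toxicity in this test:

Compound 1, `CSc1nc(NCc2ccccc2)c2ccccc2n1`: > 100000 nM

Compound 2, `COc1ccc(CNc2nc(SC)nc3ccccc23)cc1`: > 100000 nM

In this assay compound 1 gives > 100000 nM, which is a limit of the assay and not a number. Compound 2 gives > 100000 nM, again a limit rather than a number. Among the compounds with values here, the single measured step, a step that the two limits leave unreadable from compound 1 to compound 2, is therefore unreadable, since both ends sit at the same limit: the limit of > 100000 nM in this assay, at which 2 of the 2 values shown sit. Within the data shown here, compound 2 thus stands only at a limit in this assay, and the one further value shown is a limit as well.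

Compound 3, `CSc1ccc(CNc2nc(SC)nc3ccccc23)cc1`, differs from compound 2 by one change: methylsulfanyl in place of methoxy on an aromatic carbon. Among the measured compounds shown here, the only measured step that bears on a change of this kind is the one from compound 1 to compound 2, and its size cannot be read. Nothing in the measured compounds therefore gives a direction or a size for the step to compound 3 beyond the scatter. The step that the limit leaves unreadable from compound 2 to compound 3 is accordingly estimated as essentially none, with the expectation that the measurement again reports only a limit. Compound 3 is expected at about 150000 nM, within 40000 nM to 600000 nM.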

Compound 3, concentration lethal to 50% of the cells: > 100000 nM
Compound 3: a limit, no number; the forecaster's own chance of this, stated with the estimate: 80%; the middle value is on the limit's open side.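

With compound 3 also at a limit in this assay, neither its step from compound 1 nor its step from compound 2 can be read: the limit of > 100000 nM in this assay, at which 3 of the 3 values shown sit.

The compounds shown leave open what number any of the three would give, and whether methoxy or methylsulfanyl in place of hydrogen makes any difference in this assay.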